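Dropping the amino group from the aryl ether of compound 2

The compounds below may be only part of what the source reports. "The series", "measured", "known", "first", "only" and "open" are said of these compounds alone.

Compound 1 `COc1ccc(Oc2ccccc2NC(C)=C2C(=O)CC(c3ccccc3)CC2=O)cc1` gives 140 nM in a functional assay on L1210 cells (Mus musculus) for antiproliferative activity, read by cell counting, with a stated time of 96 h; on this read-out higher numbers stand for weaker inhibition and lower numbers for stronger inhibition. Within the data shown here, compound 2 `COc1cc(Oc2ccccc2NC(C)=C2C(=O)CC(c3ccccc3)CC2=O)ccc1N` gives 26 nM in this assay, the lowest of the two numbers so far; the only step, a 5.4-fold lower number from compound 1 to compound 2 (0.73 log units; beyond the scatter), brought in the 4-amino-3-methoxyphenyl group. Compound 3 `COc1cccc(Oc2ccccc2NC(C)=C2C(=O)CC(c3ccccc3)CC2=O)c1` is not yet measured; relative to compound 2 the change is hydrogen in place of amino on an aromatic carbon, so the amino leaves while the 3-methoxyphenyl pattern stays. Among the measured compounds shown here, no measured step isolates the amino alone, but the single step that added it was beyond the scatter, so a weakening of modest size is expected: a 3.5-fold higher number from compound 2 to compound 3 (0.54 log units; beyond the scatter). Compound 3 is estimated at 90 nM, range 35 nM to 250 nM.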

Compound 3, half-maximal inhibitory concentration: 58 nM
The estimate for compound 3 lay 1.6-fold (0.19 log units) above the measured number, within the range that was stated.
By their numbers in this assay, from the lowest: compound 2; then compound 3; then compound 1.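

In this assay, hydrogen in place of amino gives a 2.2-fold higher number from compound 2 to compound 3 (0.35 log units; beyond the scatter) and so separates the amino group from the rest of the 4-amino-3-methoxyphenyl change. The methoxy placement also counts on its own: 3-methoxyphenyl in place of 4-methoxyphenyl gives a 2.4-fold lower number from compound 1 to compound 3 (0.38 log units; beyond the scatter) with no amino present. Nothing available gives a reason for either step.
Open, from the compounds shown here alone, is whether a hydroxyl or a dimethylamino group on that aromatic carbon would match amino. Also open, going by these compounds, is how the ether oxygen linking the two aromatic rings compares with a methylene.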